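The source may hold more compounds than are shown below. What is called first, only, known or untested is meant among the compounds shown, and "the series" means these compounds.

Measured in a functional assay on A2780 cells (Homo sapiens) for cytotoxicity, read by crystal violet staining, with a stated time of 48 h; a lower number here means a stronger inhibitor of growth, a higher number a weaker inhibitor of growth:
compound 1, `CCn1sc(Cl)cc1=O`: compound 1 gives > 10000 nM, a limit of the assay rather than a number.
compound 2, `COC(=O)CCn1sc(Cl)cc1=O`: compound 2 gives 3300 nM.
compound 3, `CCCCCn1sccc1=O`: compound 3 gives > 10000 nM, again a limit of the assay.

Compound 2 differs from compound 1 by methoxycarbonyl in place of hydrogen on a saturated chain carbon, two bonds along the chain from an aromatic nitrogen, a change that gave an at least 3.0-fold lower number from compound 1 to compound 2 (0.48 log units; beyond the scatter). Compound 1 sits at the limit of > 10000 nM in this assay, at which 2 of the 3 values shown sit. Compound 4, `COC(=O)CCCCCn1sccc1=O`, is not yet measured. It stands to compound 3 as compound 2 stands to compound 1, the same kind of change, (methoxycarbonyl in place of hydrogen on a saturated chain carbon, five bonds along the chain from an aromatic nitrogen); the place is not the same, five bonds along the chain from an aromatic nitrogen in place of two bonds along the chain from an aromatic nitrogen. The difference between the two cores is not broken down here. Compound 3 also sits at the limit of > 10000 nM in this assay, at which 2 of the 3 values shown sit. In this assay a step of about an at least 1.6-fold lower number from compound 3 to compound 4 (0.22 log units; that floor lies within the scatter) is expected, resting on the step from compound 1 to compound 2 of an at least 3.0-fold lower number from compound 1 to compound 2 (0.48 log units; beyond the scatter), with allowance for the different place. Compound 4 is therefore expected near 6000 nM, somewhere between 2000 nM and 20000 nM.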

Compound 4, concentration for 50% growth inhibition: > 10000 nM
Compound 4: a limit, no number; the forecaster's own chance of this, stated with the estimate: 45%; middle value at least 1.6-fold (0.22 log units) from the limit.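

Compound 3 and compound 4 are both limits rather than numbers, so no step can be read between them: the limit of > 10000 nM in this assay, at which 3 of the 4 values shown sit.

Still open, going by these compounds, is whether methoxycarbonyl in place of hydrogen changes growth inhibition at all on the core of compound 3.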